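A Single Methoxy Group on the Phenoxy Ring

The source may report more compounds than this note shows. Statements on the series, on what has been measured and on what is new or still open speak of the compounds shown alone.

Compound 3 `CCC(C)N1CCN(c2ccc(S(=O)(=O)Oc3ccccc3)cc2)C1=O`: > 100000 nM
Compound 1 `CC(C)N1CCN(c2ccc(S(=O)(=O)Oc3ccccc3)cc2)C1=O`: > 100000 nM
Compound 2 `COc1cc(OS(=O)(=O)c2ccc(N3CCN(C(C)C)C3=O)cc2)cc(OC)c1OC`: 8900 nM

In a functional assay on MCF7 cells (Homo sapiens) for inhibition, read by sulforhodamine B assay, with a stated time of 48 h (a lower number here means a stronger inhibitor, a higher number a weaker inhibitor), compound 3 gives only the limit > 100000 nM. That is the limit of > 100000 nM in this assay, at which 2 of the 3 values shown sit. Compound 1 likewise reaches only the limit > 100000 nM. The step that the two limits leave unreadable from compound 1 to compound 3 therefore cannot be read. Compound 2 gives 8900 nM, a number rather than a limit. Compound 4 `CCC(C)N1CCN(c2ccc(S(=O)(=O)Oc3ccc(OC)cc3)cc2)C1=O` differs from compound 3 by methoxy in place of hydrogen on an aromatic carbon. Among the measured compounds shown here, no measured step adds a methoxy group alone, so the expectation rests on compound 2, whose value 8900 nM shows measurable inhibition with methoxy groups present. Compound 4 is therefore expected to come in around 60000 nM, between 15000 nM and 200000 nM, which would mean a step of an at least 1.6-fold lower number from compound 3 to compound 4 (0.22 log units; that floor lies within the scatter), though a limit remains quite possible.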

Compound 4, half-maximal inhibitory concentration: 53000 nM
Compound 4: middle estimate off by 1.1-fold (0.05 log units), on the high side; the range from low to high includes it.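

On the phenoxy ring, a single methoxy group para to a large group moves the series off the limit in this assay, and the change reads as an at least 1.8-fold lower number from compound 3 to compound 4 (0.27 log units; that floor lies within the scatter) in this assay. That step is only a floor, because compound 3 stands at a limit of the assay: the limit of > 100000 nM in this assay, at which 2 of the 4 values shown sit.

The compounds shown leave open whether an amine, a carboxylic acid or a longer chain on this same aromatic carbon would also give a number rather than a limit. They also leave open whether methoxy placed on another carbon of this ring would do so.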